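A few compounds are considered here, and "the series" means these few. Any claim that something is new, unique, unknown or untested is made for them only; others in the source may bear on it.

Compound 1 `COc1ccc(/C=C2\CCC/C(=C\c3ccc([N+](=O)[O-])cc3)C2=O)cc1`: 250000 nM
Compound 2 `COc1cc(/C=C2\CCC/C(=C\c3ccccc3[N+](=O)[O-])C2=O)cc(OC)c1OC`: 402 nM

In a functional assay on CCRF-CEM cells (Homo sapiens) for cytotoxicity, with a stated time of 72 h (on this read-out lower numbers stand for stronger inhibition and higher numbers for weaker inhibition), compound 2 gives 402 nM, the lowest of the two numbers. Going by the values given here, compound 1 gives 250000 nM, a gap far beyond the scatter, but the two structures differ in more than one place, so no single step links them. Compound 3 `COc1cc(/C=C2\CCC/C(=C\c3cccc([N+](=O)[O-])c3)C2=O)cc(OC)c1OC` differs from compound 2 by 3-nitrophenyl in place of 2-nitrophenyl on a double-bonded chain carbon bound to a double-bonded ring carbon. Among the compounds with values here, no measured step shows what this change does here. Compound 3 is therefore expected to land a little above compound 2, a modest step of a 3.7-fold higher number from compound 2 to compound 3 (0.57 log units; beyond the scatter) that could still fall within the scatter. The estimate for compound 3 is 1500 nM, with a range from 300 nM to 15000 nM.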

Compound 3, half-maximal inhibitory concentration in the CCRF-CEM assay: 45200 nM
Beside the measured number, compound 3's estimate is 30-fold (1.48 log units) below it; the measured number lies above the stated range.
By their numbers in the CCRF-CEM assay, from the lowest: compound 2; then compound 3; then compound 1.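

In the CCRF-CEM assay the exchange of 3-nitrophenyl for 2-nitrophenyl, the same atoms joined differently, gives a 110-fold higher number from compound 2 to compound 3 (2.05 log units; beyond the scatter) and shows that this arrangement at this place alone can move the number widely. In a physicochemical assay for lipophilicity (on this read-out lower numbers stand for lower lipophilicity and higher numbers for higher lipophilicity), compound 2 gives 4.86 and compound 3 gives 5.06 which lie within the scatter of each other. Nothing given here explains the gap in cytotoxicity.

From the compounds shown here alone, compound 1 carries 4-nitrophenyl but differs in more than one place from compound 2 and compound 3, so the effect of that group at this place remains open. Also open, going by these compounds, is what an amine in place of the nitro group would do.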